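The compounds below may be only part of what the source reports. "The series", "measured", "known", "first", "only" and "open" are said of these compounds alone.

Values in an assay on isolated protein for inhibition of tyrosine-protein phosphatase non-receptor type 13 (Homo sapiens), read by spectrophotometry; a higher number here means a weaker inhibitor, a lower number a stronger inhibitor:
compound 1, `CCN(CC)C(=O)COc1ccc2cc(C(O)(C(F)(F)F)C(F)(F)F)c(O)cc2c1`: > 20000 nM
compound 2, `O=C(COc1ccc2cc(C(O)(C(F)(F)F)C(F)(F)F)c(O)cc2c1)Nc1nc2ccccc2s1`: 9900 nM
compound 3, `COc1ccc(CNC(=O)COc2ccc3cc(C(O)(C(F)(F)F)C(F)(F)F)c(O)cc3c2)cc1OC`: > 20000 nM

In this assay compound 3 gives only a limit, > 20000 nM, and no number behind it. Compound 1 likewise stops at a limit in this assay, > 20000 nM. Among the measured compounds shown here, compound 2 is the single value read as a number in this assay, 9900 nM. The step of an at least 2.0-fold higher number from compound 2 to compound 3 (0.30 log units; that floor lies within the scatter) is thus readable only as a floor, and the step that the two limits leave unreadable from compound 1 to compound 3 cannot be read at all; note (the limit of > 20000 nM in this assay, at which 2 of the 3 values shown sit).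

Compound 4, `O=C(COc1ccc2cc(C(O)(C(F)(F)F)C(F)(F)F)c(O)cc2c1)NCc1ccccc1`, differs from compound 3 by phenyl in place of 3,4-dimethoxyphenyl on a saturated chain carbon bound to an amide-type nitrogen. Of the measured steps, only the two that end at compound 3 bear on it, and both alter the group on the amide nitrogen as a whole rather than the benzyl ring: an at least 2.0-fold higher number from compound 2 to compound 3 (0.30 log units; that floor lies within the scatter) and a step that the two limits leave unreadable from compound 1 to compound 3. Neither shows the benzylamino series reaching a number. The step that the limit leaves unreadable from compound 3 to compound 4 is expected to be none beyond the scatter. Compound 4 is expected to sit at or near the limit and is estimated at 25000 nM, with a range from 9000 nM to 60000 nM, pending the measurement.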

Compound 4, half-maximal inhibitory concentration: > 20000 nM
Compound 4: only a limit was reported; the forecaster's own chance of this, stated with the estimate: 65%; the middle value does not contradict the limit.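

In this assay compound 4, with phenyl in place of 3,4-dimethoxyphenyl, gives only a limit (> 20000 nM), so the simpler benzylamino compound also yields no number. Compared with the one numeric value in the series, the only readable step is an at least 2.0-fold higher number from compound 2 to compound 4 (0.30 log units; that floor lies within the scatter) and gives a floor, not a size. The steps to compound 4 from compound 3 and from compound 1 cannot be read, and the series now piles up at one assay limit, leaving the 3,4-dimethoxy substitution without a measurable effect here: the limit of > 20000 nM in this assay, at which 3 of the 4 values shown sit.

As far as these compounds go, it remains open whether compound 2 truly stands apart from the benzylamino compounds by more than the scatter, since every comparison with it so far rests on a floor that lies within the scatter. From the compounds shown here alone, it is also open whether a carboxylic acid or an amine on the benzyl ring, or a longer chain between the amide nitrogen and the phenyl, would bring this series down to a readable value.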